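Moving the Nitro Group Around the Benzamide Ring

The source may report more compounds than this note shows. Statements on the series, on what has been measured and on what is new or still open speak of the compounds shown alone.

Of the compounds shown here, two have been measured in an assay on microsomes from liver for inhibition of sterol O-acyltransferase 1 (Rattus norvegicus); a lower number here means a stronger inhibitor, a higher number a weaker inhibitor. Compound 1 `CCCCCCCCCCCCn1nnc(C(NC(=O)c2ccccc2)c2ccccc2)n1` gives 350 nM. Compound 2 `CCCCCCCCCCCCn1nnc(C(NC(=O)c2cccc([N+](=O)[O-])c2)c2ccccc2)n1` carries a nitro group where compound 1 has a hydrogen on an aromatic carbon; in this assay compound 2 gives 80 nM. Among the compounds with values here, that single change is a 4.4-fold lower number from compound 1 to compound 2 (0.64 log units; beyond the scatter), so compound 2 stands as the stronger of the two, with compound 1 the only point of comparison.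

Compound 3 `CCCCCCCCCCCCn1nnc(C(NC(=O)c2ccccc2[N+](=O)[O-])c2ccccc2)n1` differs from compound 2 only in where that nitro group sits: 2-nitrophenyl in place of 3-nitrophenyl on a carbonyl carbon. Within the data shown here, no measured pair shows what relocating the nitro group does; the one step known, a 4.4-fold lower number from compound 1 to compound 2 (0.64 log units; beyond the scatter), concerns adding the group, not moving it. The expectation therefore rests on that single step, which shows the nitro group helpful where it sits in compound 2 but says nothing about the new place. Compound 3 is expected to stay near compound 2 or fall somewhat behind it. This amounts to an estimated 1.9-fold higher number from compound 2 to compound 3 (0.27 log units; within the scatter). In this assay compound 3 is estimated at 150 nM, within a range from 40 nM to 600 nM.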

Compound 3, half-maximal inhibitory concentration: 240 nM
For compound 3 the middle estimate is 1.6-fold (0.20 log units) below the measured one, and the stated range covers the measured number.
By their numbers in this assay, from the lowest: compound 2; then compounds 3 and 1 (each within the scatter of the next).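

Moving the nitro group from 3-nitrophenyl to 2-nitrophenyl on the carbonyl carbon gives, in this assay, a 3.0-fold higher number from compound 2 to compound 3 (0.48 log units; beyond the scatter) and this shows that the group's place on the ring matters, not just its presence. Adding the nitro group in this other place gives a 1.5-fold lower number from compound 1 to compound 3 (0.16 log units; within the scatter) so the clear gain seen with 3-nitrophenyl does not carry over to 2-nitrophenyl, and the new place offers no measurable advantage over having no nitro group at all. Nothing available explains why the two places differ.

The compounds shown leave open whether the gain belongs to the nitro group itself or could also come from another group at the place it holds in compound 2, such as a nitrile, a trifluoromethyl or an amine. They also leave open how much of the activity depends on the long alkyl chain shared by compound 1, compound 2 and compound 3, which a shorter chain would test.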